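Replacing dichlorophenyl with difluorophenyl on the piperazine-like ring

A few compounds are considered here, and "the series" means these few. Any claim that something is new, unique, unknown or untested is made for them only; others in the source may bear on it.

In a functional assay on CHO cells with adenosine receptor A1 (Homo sapiens) as the target, read by cAMP accumulation and immunoassay, with a stated time of 6 min, tested at 10 uM (a lower number here means a stronger effect, a higher number a weaker effect of the compound at the concentration tested), compound 1 `Nc1scc(CN2CCN(c3cc(Cl)cc(Cl)c3)CC2)c1C(=O)c1ccc(Cl)cc1` gives -74%, the second highest of three numbers. Compound 2 `Nc1scc(CN2CCN(c3cccc(C(F)(F)F)c3)CC2)c1C(=O)c1ccc(Cl)cc1` gives -80%, and compound 3 `Nc1scc(CN2CCN(c3cccc4ccccc34)CC2)c1C(=O)c1ccc(Cl)cc1` gives -21%. Compound 4 `Nc1scc(CN2CCN(c3ccc(F)c(F)c3)CC2)c1C(=O)c1ccc(Cl)cc1` differs from compound 1 by 3,4-difluorophenyl in place of 3,5-dichlorophenyl on an amine nitrogen in a ring. The step of a number 6 percentage points lower from compound 1 to compound 2 (within the scatter) shows that exchanging one substituted phenyl group for another on this nitrogen left the number within the scatter, whereas a number 53 percentage points higher from compound 1 to compound 3 (beyond the scatter) and a number 59 percentage points higher from compound 2 to compound 3 (beyond the scatter) show that only the bicyclic naphthalen-1-yl moved it far. Since compound 4 keeps a substituted phenyl, no step beyond the scatter is expected, and the estimated change a number 8 percentage points higher from compound 1 to compound 4 (within the scatter) is small. Compound 4 is therefore expected to give about -66%, in a range from -88% to -36%.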

Compound 4, a percentage reported as activity, at one concentration (the size of the read-out at that concentration, not a potency): -87%
Compound 4: middle estimate off by 21 percentage points, on the high side; the range from low to high includes it.
By their numbers in this assay, from the lowest: compounds 4, 2 and 1 (each within the scatter of the next, the first and the last beyond it); then compound 3.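

In this assay, 3,4-difluorophenyl in place of 3,5-dichlorophenyl gives a number 13 percentage points lower from compound 1 to compound 4 (beyond the scatter), so one substituted phenyl group exchanged for another on this nitrogen can move the number past the scatter, which the earlier phenyl pair did not show. The step of a number 7 percentage points lower from compound 2 to compound 4 (within the scatter) stays small, while a number 66 percentage points lower from compound 3 to compound 4 (beyond the scatter) is large, leaving compound 3 the only clear outlier among these four. No measurement here explains these differences.

The halogen and its ring pattern change together in this step, and the compounds shown do not separate the two. On these data alone, how an unsubstituted phenyl, a methoxyphenyl or a pyridine ring would behave on this nitrogen also stays open.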